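The source may report more compounds than this note shows. Statements on the series, on what has been measured and on what is new or still open speak of the compounds shown alone.

Three compounds have been measured in a functional assay on MGC-803 cells (Homo sapiens) for antiproliferative activity, read by MTT assay, with a stated time of 48 h; a higher number here means a weaker inhibitor, a lower number a stronger inhibitor:

Compound 1 `COc1ccc(NC(=O)Nc2cccc(CNc3nccnc3Cl)c2)cc1` gives 9240 nM.
Compound 2 `O=C(Nc1ccc(Cl)cc1)Nc1cccc(CNc2nccnc2Cl)c1` gives 4980 nM.
Compound 3 `O=C(Nc1cccc(Cl)c1)Nc1cccc(CNc2nccnc2Cl)c1` gives 5330 nM.

Compound 2 has the lowest of these three numbers, but only narrowly: the steps of a 1.9-fold lower number from compound 1 to compound 2 (0.27 log units; within the scatter) and a 1.1-fold higher number from compound 2 to compound 3 (0.03 log units; within the scatter) both lie within the scatter, as does a 1.7-fold lower number from compound 1 to compound 3 (0.24 log units; within the scatter), so none of the three can be placed above or below the others with confidence. All three share the same core and differ only in the group carried on one amide-type nitrogen.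

Compound 4 `O=C(Nc1cccc(CNc2nccnc2Cl)c1)Nc1ccc(Cl)c(Cl)c1` keeps the group of compound 2 and adds to it: chloro in place of hydrogen on an aromatic carbon. The added chloro sits ortho to the chloro already present, so that 4-chlorophenyl becomes 3,4-dichlorophenyl.

Going by the values given here, two measured steps touch on this ring. The step of a 1.9-fold lower number from compound 1 to compound 2 (0.27 log units; within the scatter) shows that exchanging methoxy for chloro there moved the number only within the scatter, and a 1.1-fold higher number from compound 2 to compound 3 (0.03 log units; within the scatter) shows that shifting the chloro to another position changed nothing beyond the scatter. Among the compounds with values here, no measured step adds a second chloro. A small step toward a lower number, or none beyond the scatter, is therefore expected. The expected step is a 1.4-fold lower number from compound 2 to compound 4 (0.15 log units; within the scatter). Compound 4 is estimated to give about 3500 nM, most likely between 1500 nM and 9000 nM.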

Compound 4, half-maximal inhibitory concentration: 4970 nM
The estimate for compound 4 lay 1.4-fold (0.15 log units) below the measured number; low and high end bracket the measured number.
By their numbers in this assay, from the lowest: compounds 4, 2, 3 and 1 (each within the scatter of the next).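

The earlier compounds shown here carry a single group on this ring, so they could not show what a second one does; in this assay, the chloro that turns 4-chlorophenyl into 3,4-dichlorophenyl gives a 1.0-fold lower number from compound 2 to compound 4 (0.00 log units; within the scatter). Read from the other single-chloro compound, the same kind of addition gives a 1.1-fold lower number from compound 3 to compound 4 (0.03 log units; within the scatter), and the exchange of 4-methoxyphenyl for 3,4-dichlorophenyl gives a 1.9-fold lower number from compound 1 to compound 4 (0.27 log units; within the scatter), so all three steps stay within the scatter and this ring has so far accepted one or two chloro groups without a readable change in the number. No measurement shown here offers an explanation for this result.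

The compounds shown carry only chloro or methoxy on this ring, so it remains open whether a very different group there, such as an amine, a carboxylic acid or a longer chain, would move the number beyond the scatter. As far as these compounds go, it also remains open whether changes to the shared core, rather than to this ring, would do so.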